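Aryl variation on the shared core: compound 2 to compound 3

The source may hold more compounds than are shown below. What is called first, only, known or untested is meant among the compounds shown, and "the series" means these compounds.

Compound 1 `c1ccc2c(-c3cn4ccnc4c(-c4ccc5ncn(C6CCCCC6)c5c4)n3)cccc2c1` gives 22.9% in a functional assay on RPMI-8226 cells (Homo sapiens) for inhibition, read by sulforhodamine B assay, with a stated time of 48 h, tested at 10 uM; a higher number here means more inhibition at the concentration tested (going by the name of the read-out), a lower number less inhibition. For the measured compounds named here, compound 2 `Brc1ccc(-c2cn3ccnc3c(-c3ccc4ncn(C5CCCCC5)c4c3)n2)cc1` gives 32.1% in this assay, the higher of the two numbers so far, although the step of a number 9.2 percentage points higher from compound 1 to compound 2 (within the scatter) lies within the scatter. Compound 3 `FC(F)(F)c1cccc(-c2cn3ccnc3c(-c3ccc4ncn(C5CCCCC5)c4c3)n2)c1` carries the change (3-(trifluoromethyl)phenyl in place of 4-bromophenyl on an aromatic carbon). Going by the values given here, only that one step bears on this position, and it stayed within the scatter, so no change beyond the scatter is expected in this assay. Compound 3 is estimated at 30% in this assay, within 15% to 45%. The expected step is a number 2.1 percentage points lower from compound 2 to compound 3 (within the scatter).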

Compound 3, a percentage reported as inhibition, at one concentration (the size of the read-out at that concentration, not a potency): 32.1%
The estimate for compound 3 lay 2.1 percentage points below the measured number; the measured number falls inside the stated range.
By their numbers in this assay, from the lowest: compounds 1, 2 and 3 (each within the scatter of the next).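

In this assay, 3-(trifluoromethyl)phenyl in place of 4-bromophenyl gives no change at the digits printed from compound 2 to compound 3 (within the scatter), and in place of naphthalen-1-yl it gives a number 9.2 percentage points higher from compound 1 to compound 3 (within the scatter). At this aromatic carbon, the three aryl groups therefore cannot be separated, even with a different substituent and substitution pattern on the phenyl ring. No measurement offered here accounts for this result.

Still open, going by these compounds, is whether a basic amine or a carboxylic acid on the phenyl ring would produce a step beyond the scatter. A single-concentration read-out also leaves the potency of these compounds undefined.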